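Hydroxy for Methyl on the Sulfonamide Ring

This account rests on a few compounds, and the source may have more. Where it says the series, first, only, none or still open, it means among the compounds named here.

Compound 1 `CCCCCCS(=O)(=O)N[C@H]1C2CC[C@H](C2)[C@@H]1C/C=C\CCCC(=O)O` gives 13300 nM in a functional assay (plasma) for inhibition, with Oryctolagus cuniculus as the target; on this read-out higher numbers stand for weaker inhibition and lower numbers for stronger inhibition.
Compound 2 `Cc1ccc(S(=O)(=O)N[C@H]2C3CC[C@H](C3)[C@@H]2C/C=C\CCCC(=O)O)cc1` gives 500 nM in this assay.
Compound 3 `O=C(O)CCC/C=C\C[C@H]1[C@@H]2CCC(C2)[C@@H]1NS(=O)(=O)c1ccccc1` gives 1000 nM; 7400 nM; 600 nM (3 entries) in this assay.

Among the single numbers, compound 2 stands lowest, its nearest neighbour being compound 1, which lies a 27-fold lower number from compound 1 to compound 2 (1.42 log units; beyond the scatter) away. Compound 3 carries no single number but three entries, and the spread of those entries the several entries of compound 3 in this assay, 1000 nM; 7400 nM; 600 nM (3 entries) shows how far repeats of this assay can drift.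

Compound 4 `O=C(O)CCC/C=C\C[C@H]1[C@@H]2CCC(C2)[C@@H]1NS(=O)(=O)c1ccc(O)cc1` differs from compound 2 by hydroxy in place of methyl on an aromatic carbon. Among the measured compounds shown here, no measured step alters a group on the aromatic ring; the only measured step, a 27-fold lower number from compound 1 to compound 2 (1.42 log units; beyond the scatter), replaces hexyl with 4-methylphenyl on the sulfonyl sulfur, a change of another kind. Compound 3, the plain phenyl sulfonamide, and compound 2, its 4-methylphenyl counterpart, give numbers that overlap once the three entries of compound 3 are taken together. From this the step from compound 2 to compound 4 is expected to be small, at most a modest drift toward weaker inhibition, and not clearly beyond the scatter: a 1.6-fold higher number from compound 2 to compound 4 (0.20 log units; within the scatter). Compound 4 is therefore estimated at 800 nM in this assay. The range for compound 4 is expected to run from 250 nM to 2500 nM.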

Compound 4, half-maximal inhibitory concentration: 500 nM
Beside the measured number, compound 4's estimate is 1.6-fold (0.20 log units) above it, within the range that was stated.
By their numbers in this assay, from the lowest: compounds 2 and 4 (each within the scatter of the next); then compound 1.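

Among the compounds shown here, until this result, no measured step had changed a group on the aromatic ring. In this assay, replacing methyl with hydroxy at the carbon para to a large group gives no change at the digits printed from compound 2 to compound 4 (within the scatter), so this position accepts a hydrogen-bond donor and acceptor in place of a plain carbon group without a visible loss of inhibition. The advantage of the aromatic sulfonamide over the hexyl one also survives the swap, with a 27-fold lower number from compound 1 to compound 4 (1.42 log units; beyond the scatter) matching a 27-fold lower number from compound 1 to compound 2 (1.42 log units; beyond the scatter), so this advantage does not depend on the methyl group. Even so, the flat step excludes only a large effect, since repeats of a single compound spread widely here: the several entries of compound 3 in this assay, 1000 nM; 7400 nM; 600 nM (3 entries)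

From the compounds shown here alone, whether the position would accept other groups, such as an amine, a carboxylic acid or a methoxy group, stays open, and two groups are too few to support a general rule. It is also unknown whether a hydroxy group placed elsewhere on the aromatic ring, or at the end of a longer chain in place of the ring, would give a similar number.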